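This account rests on a few compounds, and the source may have more. Where it says the series, first, only, none or still open, it means among the compounds named here.

Compound 1 `Cc1ccc(NC(=O)Nc2cccc(CNc3nccnc3Cl)c2)cc1` gives 11900 nM in a functional assay on MGC-803 cells (Homo sapiens) for antiproliferative activity, read by MTT assay, with a stated time of 48 h; on this read-out higher numbers stand for weaker inhibition and lower numbers for stronger inhibition. Compound 2 `O=C(Nc1cccc(CNc2nccnc2Cl)c1)Nc1ccccc1Cl` gives 7130 nM. Compound 3 `CCOc1ccc(NC(=O)Nc2cccc(CNc3nccnc3Cl)c2)cc1` gives 7240 nM.

Compound 2 shows the lowest number of the three, but its separation from the others is small: a 1.7-fold lower number from compound 1 to compound 2 (0.22 log units; within the scatter) and a 1.0-fold higher number from compound 2 to compound 3 (0.01 log units; within the scatter) both lie within the scatter, so the three compounds cannot be told apart on these numbers. The unmeasured compound 4 `O=C(Nc1cccc(CNc2nccnc2Cl)c1)NC1CCCC1` differs from compound 2 only in cyclopentyl in place of 2-chlorophenyl on an amide-type nitrogen. Unlike the earlier exchanges, the entering group carries no aromatic ring.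

Among the compounds with values here, two measured steps bear on this position: a 1.7-fold lower number from compound 1 to compound 2 (0.22 log units; within the scatter) and a 1.0-fold higher number from compound 2 to compound 3 (0.01 log units; within the scatter) both exchange the group on the amide-type nitrogen among substituted phenyl rings, and neither moves the number beyond the scatter. Within the data shown here, no measured step replaces an aromatic ring at this position with a non-aromatic one, so there is no direct precedent. The shared core of compounds 1, 2 and 3 is unchanged in compound 4. It is therefore expected that compound 4 gives a number close to compound 2, with a 1.3-fold higher number from compound 2 to compound 4 (0.10 log units; within the scatter), and a somewhat wider range to allow for the untested ring type. Compound 4 is estimated at 9000 nM, between 3500 nM and 25000 nM.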

Compound 4, half-maximal inhibitory concentration: 23400 nM
Compound 4: middle estimate off by 2.6-fold (0.41 log units), on the low side; the measured number falls inside the stated range.
By their numbers in this assay, from the lowest: compounds 2, 3, 1 and 4 (each within the scatter of the next, the first and the last beyond it).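

In this assay, the group on the amide-type nitrogen had produced no step beyond the scatter while one substituted phenyl ring was exchanged for another, but cyclopentyl gives a 3.3-fold higher number from compound 2 to compound 4 (0.52 log units; beyond the scatter) and a 3.2-fold higher number from compound 3 to compound 4 (0.51 log units; beyond the scatter), so the first separation at this position comes with a non-aromatic ring. The result does not hold across all three phenyl compounds: compound 1 goes against it, with a 2.0-fold higher number from compound 1 to compound 4 (0.29 log units; within the scatter) remaining within the scatter, so the modest loss is seen only against the 2-chlorophenyl and 4-ethoxyphenyl compounds. Nothing available explains the difference between the aromatic rings and cyclopentyl at this position.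

The compounds shown leave open whether this result belongs to cyclopentyl alone or extends to other non-aromatic groups on this nitrogen, such as cyclohexyl, an open butyl chain or a piperidine ring. They also leave open whether a phenyl ring carrying an amine or a carboxylic acid would separate from compound 2 in this assay, since all of the phenyl rings shown stay within the scatter of one another.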